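A few compounds are considered here, and "the series" means these few. Any claim that something is new, unique, unknown or untested is made for them only; others in the source may bear on it.

Compound 1 `O=C(Nc1cccc(-n2cc(-c3ccncc3)c(-c3ccc(Cl)c(O)c3)n2)c1)Nc1ccc(Cl)c(Cl)c1` stops at a limit of the assay rather than a number: in a functional assay on HCT-116 cells (Homo sapiens) for inhibition, read by sulforhodamine B assay, with a stated time of 48 h (a higher number here means that more compound is tolerated, a lower number that less compound is tolerated), compound 1 gives > 32500 nM. Compound 2 `COc1cc(-c2nn(-c3cccc(NC(=O)c4cccc(C(F)(F)F)c4)c3)cc2-c2ccncc2)ccc1Cl` also reaches only a limit, and compound 2 gives > 50000 nM. Compound 3 `COc1cc(-c2nn(-c3cccc(NC(=O)Nc4cccc(C(F)(F)F)c4)c3)cc2-c2ccncc2)ccc1Cl` stands in the same place on the numbers shown, at a limit alone, and compound 3 gives > 50000 nM. Among the three values shown there is thus no number at all, only the limit of > 32500 nM in this assay, at which 1 of the 3 values shown sits, and (the limit of > 50000 nM in this assay, at which 2 of the 3 values shown sit). For the measured compounds named here, the single step that joins two measured compounds, a step that the two limits leave unreadable from compound 2 to compound 3, cannot be read, since both of its ends are limits.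

Compound 4 `COc1cc(-c2nn(-c3cccc(NC(=O)c4ccccc4)c3)cc2-c2ccncc2)ccc1Cl` differs from compound 3 by phenyl in place of (3-(trifluoromethyl)phenyl)amino on a carbonyl carbon. Going by the values given here, no measured step bears on this change, and the one related step is unreadable, so nothing in the data points toward a shift in either direction. He therefore expects no step beyond the scatter in this assay, the expected step being a number no higher from compound 3 to compound 4 (the limit leaves the size open), with compound 4 most likely again ending at a limit. Compound 4 is estimated at 50000 nM, within a range from 20000 nM to 120000 nM.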

Compound 4, concentration lethal to 50% of the cells: > 100000 nM
Compound 4: no number, only a limit; the forecaster's own chance of this, stated with the estimate: 80%; middle value at least 2.0-fold (0.30 log units) away from the limit.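

In this assay compound 4 gives > 100000 nM, again a limit and not a number. Its steps from compound 2 and from compound 3 therefore cannot be read. The compounds shown leave open whether any of these changes moves the read-out at all, as none yields a number.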